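The compounds below may be only part of what the source reports. "The series", "measured", "known", "first", "only" and "open" are said of these compounds alone.

Compound 1 `CCCCCOc1cc(C(C)(C)C)ccc1C/N=C(\S)NCc1ccc(NS(C)(=O)=O)cc1`: 70 nM
Compound 2 `CC(C)(C)COc1cc(C(C)(C)C)ccc1C/N=C(\S)NCc1ccc(NS(C)(=O)=O)cc1`: 60 nM

In a functional assay for inhibition of Vanilloid receptor (Rattus norvegicus) (on this read-out lower numbers stand for stronger inhibition and higher numbers for weaker inhibition), compound 2 and compound 1 cannot be told apart, since the change a 1.2-fold lower number from compound 1 to compound 2 (0.07 log units; within the scatter) stays within the scatter. Compound 3 `CC(C)(C)C(=O)OCc1cc(C(C)(C)C)ccc1C/N=C(\S)NCc1ccc(NS(C)(=O)=O)cc1` differs from compound 2 by (((tert-butyl)carbonyl)oxy)methyl in place of neopentyloxy on an aromatic carbon. Among the measured compounds shown here, the single measured step only varied the chain on the ring oxygen and so bears weakly on a change that replaces the oxygen-linked chain with an ester-bearing group. For the measured compounds named here, with no closer precedent, compound 3 is expected to come out near compound 2, with a wide band: the estimated step is a 2.5-fold higher number from compound 2 to compound 3 (0.40 log units; beyond the scatter), giving an expected 150 nM (range 40 nM to 600 nM).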

Compound 3, half-maximal inhibitory concentration: 70 nM
Compound 3: middle estimate off by 2.1-fold (0.33 log units), on the high side; the measured number falls inside the stated range.
By their numbers in this assay, from the lowest: compounds 2, 1 and 3 (each within the scatter of the next).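

In this assay the (((tert-butyl)carbonyl)oxy)methyl group replaces neopentyloxy with a 1.2-fold higher number from compound 2 to compound 3 (0.07 log units; within the scatter) and replaces pentyloxy with no change at the digits printed from compound 1 to compound 3 (within the scatter) as its result. This position, on an aromatic carbon ortho to a large group, therefore accepts a carbonyl-containing group with no oxygen bound directly to the ring, and the read-out stays within the scatter across all three compounds. No supporting data explain this tolerance. As far as these compounds go, whether an amine, a carboxylic acid or a much longer chain would be tolerated here remains open.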